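The source may report more compounds than this note shows. Statements on the series, on what has been measured and on what is new or still open speak of the compounds shown alone.

Measured compounds:
compound 1, `COc1ccccc1OCCNC[C@H](O)COc1ccc(OC)c2[nH]ccc12` — 0.53 mg/kg
compound 2, `COc1ccccc1OCCNC[C@@H](O)COc1c(OC)ccc2[nH]ccc12` — 0.16 mg/kg

In a functional assay on the whole organism (heart, strain Wistar) for inhibition, with Rattus norvegicus as the target, with a stated time of 15 min, at a dose of 1 mg/kg by the intravenous route (on this read-out higher numbers stand for an effect only at larger amounts of compound and lower numbers for an effect already at smaller amounts), compound 1 gives 0.53 mg/kg, the highest of the two numbers, while compound 2 gives 0.16 mg/kg, a gap that lies beyond the usual scatter. The two measured compounds differ in more than one place, so their values are simply set side by side here.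

Compound 3, `COc1ccccc1OCCNC[C@@H](O)COc1ccc(OC)c2[nH]ccc12`, has not been measured. From compound 1 to compound 3 the change is the two compounds have the same atoms and bonds and differ only in configuration as drawn: 1 of 1 stereo elements differ; a stereocentre at a saturated chain carbon is drawn S in compound 1 and R in compound 3. For the measured compounds named here, no measured pair isolates such a change of configuration alone, so the size of the step is open. Compound 3 is drawn in the same configuration as compound 2. Because compound 2 gives 0.16 mg/kg, a step toward a lower number is expected, though a wide range is kept. Compound 3 is estimated at 0.25 mg/kg, between 0.05 mg/kg and 2 mg/kg. This expectation corresponds to the step of a 2.1-fold lower number from compound 1 to compound 3 (0.33 log units; beyond the scatter).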

Compound 3, dose for half-maximal effect: 0.38 mg/kg
Beside the measured number, compound 3's estimate is 1.5-fold (0.18 log units) below it; the range from low to high includes it.
By their numbers in this assay, from the lowest: compound 2; then compounds 3 and 1 (each within the scatter of the next).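

In this assay, redrawing the stereocentre at a saturated chain carbon from S to R gives a 1.4-fold lower number from compound 1 to compound 3 (0.14 log units; within the scatter). For the compounds shown here, this is the first step here that isolates configuration, and it can be read that way for one reason: the fact that compounds 1 and 3 differ only in the configuration as drawn. On the core shared by this pair, the read-out therefore gives no sign that the configuration at this stereocentre separates the two forms, although a step of this size cannot rule out a small real difference.

On these data alone, whether the change of configuration would stay this small with a chlorine or an ethoxy group in place of the methoxy group on the core remains open. The same question stands for a longer chain in place of the ethyl chain that carries the amine.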